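This account rests on a few compounds, and the source may have more. Where it says the series, first, only, none or still open, it means among the compounds named here.

Measured so far in a functional assay on MGC-803 cells (Homo sapiens) for inhibition, read by MTT assay, with a stated time of 72 h; on this read-out higher numbers stand for weaker inhibition and lower numbers for stronger inhibition:
- compound 1 (`Cc1ccc(N2CCCC2)c(C(=O)Nc2ccc(CNC(=O)OCc3cccnc3)cc2)c1`): 19100 nM
- compound 2 (`COc1ccc(N2CCCC2)c(C(=O)Nc2ccc(CNC(=O)OCc3cccnc3)cc2)c1`): 85700 nM

Of these two compounds, compound 1 has the lower number, 19100 nM, so it is the stronger inhibitor of the pair. Compound 3 (`O=C(NCc1ccc(NC(=O)c2cc(Br)ccc2N2CCCC2)cc1)OCc1cccnc1`) has not yet been measured. Its difference from compound 1 lies in one place: bromo in place of methyl on an aromatic carbon. In words, this is bromo in place of methyl on an aromatic carbon, para to a pyrrolidin-1-yl group.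

Within the data shown here, only one measured step bears on this change. Methoxy in place of methyl on that same carbon gives a 4.5-fold higher number from compound 1 to compound 2 (0.65 log units; beyond the scatter), a modest change. Among the measured compounds shown here, it shows that the number can respond to a swap at this carbon, but bromo is a different group, and no bromo compound has been measured for comparison. A smaller move towards a higher number therefore seems most likely, with no step beyond the scatter expected in this assay. The expected change is a 1.4-fold higher number from compound 1 to compound 3 (0.13 log units; within the scatter). For compound 3 the estimated value is 26000 nM, with an expected range from 8000 nM to 80000 nM.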

Compound 3, half-maximal inhibitory concentration: 45700 nM
For compound 3 the middle estimate is 1.8-fold (0.24 log units) below the measured one; measured number inside the range.
By their numbers in this assay, from the lowest: compound 1; then compounds 3 and 2 (each within the scatter of the next).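

In this assay the change from methyl to bromo on this aromatic carbon, para to a pyrrolidin-1-yl group, gives a 2.4-fold higher number from compound 1 to compound 3 (0.38 log units; beyond the scatter) and so adds a second group, after methoxy, that leaves the number higher than methyl does, which makes compound 1 the strongest inhibitor of the three. The comparison of the two replacement groups gives a 1.9-fold lower number from compound 2 to compound 3 (0.27 log units; within the scatter) and lies within the usual scatter, so bromo and methoxy cannot be told apart at this carbon in this assay. No measurement at hand explains why methyl gives the lowest number of the three.

Still open is whether any group at this carbon can bring the number below that of methyl, since the compounds shown carry only methyl, methoxy and bromo here and include no chloro, fluoro, ethyl or plain hydrogen. Also open, from the compounds shown here alone, is whether methyl would keep its place with something else in place of the pyrrolidin-1-yl group, such as a morpholine or a dimethylamino group.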